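This account rests on a few compounds, and the source may have more. Where it says the series, first, only, none or still open, it means among the compounds named here.

Measured so far:
compound 1 `CN(C)CCNc1nc(-c2ccc(NC(=O)Nc3ccc(Cl)cc3Cl)cc2)nc2c(Cl)c(Cl)sc12`: in a functional assay on MDA-MB-231 cells (Homo sapiens) for cytotoxicity, read by MTT assay, with a stated time of 72 h (a lower number here means a stronger inhibitor, a higher number a weaker inhibitor), compound 1 gives 3500 nM
compound 2 `CCN(CC)CCCNc1nc(-c2ccc(NC(=O)Nc3ccccc3Cl)cc2)nc2c(Cl)c(Cl)sc12`: in this assay compound 2 gives 970 nM
compound 3 `CCN(CC)CCCNc1nc(-c2ccc(NC(=O)Nc3ccc(Cl)cc3Cl)cc2)nc2c(Cl)c(Cl)sc12`: in this assay compound 3 gives 3940 nM

Compound 3 holds the highest of the three numbers in this assay. Its nearest neighbour is separated from it by a 1.1-fold higher number from compound 1 to compound 3 (0.05 log units; within the scatter), a gap that does not leave the scatter; the furthest is reached by a 4.1-fold higher number from compound 2 to compound 3 (0.61 log units; beyond the scatter).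

Compound 4 `CCN(CC)CCNc1nc(-c2ccc(NC(=O)Nc3ccc(Cl)cc3Cl)cc2)nc2c(Cl)c(Cl)sc12` has not been measured. Relative to compound 3 the change is diethylamino in place of (diethylamino)methyl on a saturated chain carbon, two bonds along the chain from a nitrogen on an aromatic ring. The chain between the nitrogen on the aromatic ring and the terminal amine is cut shorter while the diethylamino terminus is kept, so compound 4 carries the chain length of compound 1 together with the amine of compound 3. Within the data shown here, the only measured step touching this part of the molecule is a 1.1-fold higher number from compound 1 to compound 3 (0.05 log units; within the scatter), in which the terminal amine changed without any move beyond the scatter. The other step, a 4.1-fold higher number from compound 2 to compound 3 (0.61 log units; beyond the scatter), concerns a chloro in place of hydrogen on an aromatic carbon and does not bear on the chain. With a single relevant step, and that one small, no step beyond the scatter is expected in this assay; the expected step is a 1.1-fold lower number from compound 3 to compound 4 (0.05 log units; within the scatter). Compound 4 is estimated at 3500 nM in this assay, with a range of 1500 nM to 8000 nM.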

Compound 4, half-maximal inhibitory concentration: 1920 nM
Beside the measured number, compound 4's estimate is 1.8-fold (0.26 log units) above it; the measured number falls inside the stated range.
By their numbers in this assay, from the lowest: compounds 2, 4, 1 and 3 (each within the scatter of the next, the first and the last beyond it).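

In this assay, the result separates chain length from the terminal amine, which the earlier step from compound 1 to compound 3 could not do, as that step changed both at once and stayed within the scatter. With the diethylamino terminus held constant, going from the 3-(diethylamino)propyl chain to the 2-(diethylamino)ethyl chain gives a 2.1-fold lower number from compound 3 to compound 4 (0.31 log units; beyond the scatter), a modest step that only just clears the scatter, while at the shorter chain length, exchanging dimethylamino for diethylamino gives a 1.8-fold lower number from compound 1 to compound 4 (0.26 log units; within the scatter), so these two terminal amines are not separated at that length in this series. Chain length is therefore the one change at this position with a step beyond the scatter so far, though nothing available explains that step.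

From the compounds shown here alone, these notes rest on a single pair for chain length, so it remains open whether the same shortening carries over to the urea side of compound 2, which has the lowest number of the set. Also open, going by these compounds, is how a longer chain carrying diethylamino, or a morpholine in place of the diethylamino terminus, would read on the same core.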